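The source may hold more compounds than are shown below. What is called first, only, known or untested is meant among the compounds shown, and "the series" means these compounds.

Two compounds have been examined in an assay on membranes from HEK293T cells for inhibition of presenilin-associated rhomboid-like protein, mitochondrial (Homo sapiens), with a stated time of 30 min; on this read-out lower numbers stand for stronger inhibition and higher numbers for weaker inhibition. Compound 1 `O=C1CCC(=O)N1S(=O)(=O)c1ccc([N+](=O)[O-])cc1` gives 900 nM in this assay, while compound 2 `O=C1CCC(=O)N1OS(=O)(=O)c1ccccc1` gives 20000 nM. Among the two numbers, compound 2 has the higher one, and its gap to compound 1 lies beyond the usual scatter of repeated measurements, so compound 2 is the weaker inhibitor of the pair.

Compound 3 `O=C1CCC(=O)N1OS(=O)(=O)c1ccc(-c2ccccc2)cc1` is built from compound 2 by one change: phenyl in place of hydrogen on an aromatic carbon. The phenyl enters on an aromatic carbon of a six-membered aromatic ring of carbon only, para to a large group.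

Within the data shown here, no measured pair shows what such a change does here, so the expectation rests on the two numbers above. A modest move toward a lower number in this assay is expected, within a step of a 3.3-fold lower number from compound 2 to compound 3 (0.52 log units; beyond the scatter). Compound 3 is estimated at 6000 nM, with a range from 1500 nM to 25000 nM.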

Compound 3, half-maximal inhibitory concentration: 1900 nM
Compound 3: the middle estimate sits 3.2-fold (0.50 log units) above what was measured, within the range that was stated.
By their numbers in this assay, from the lowest: compound 1; then compound 3; then compound 2.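

In this assay, phenyl in place of hydrogen on an aromatic carbon, para to a large group, gives an 11-fold lower number from compound 2 to compound 3 (1.02 log units; beyond the scatter) in this series. The earlier compounds shown here differed in more than one place, so they could not show what a single change does; this step shows that this position accepts a whole added six-membered aromatic ring of carbon only, and that the number falls rather than rises. No measurement at hand explains why the step is this large.

The compounds shown leave open whether a ring is needed here at all, a question that a methyl group, an amine or a carboxylic acid on the same carbon could answer. They also leave open whether phenyl would lower the number in the same way on the core of compound 1.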